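This account rests on a few compounds, and the source may have more. Where it says the series, first, only, none or still open, it means among the compounds named here.

Compound 2, `Cc1n[nH]c2ccc(-c3nc4cnc(N5CCN(C)CC5)cn4c3Nc3ccc(Cl)cc3)cc12`, gives 8.11% in a functional assay on CWR22R cells (Homo sapiens) for inhibition, with a stated time of 120 h, tested at 10 uM; a lower number here means less inhibition, a higher number more inhibition at the concentration tested (going by the name of the read-out).
Compound 1, `Cc1n[nH]c2ccc(-c3nc4cnc(N5CCN(C)CC5)cn4c3Nc3cccc(F)c3)cc12`, gives 5.41%.
Compound 3, `Cc1n[nH]c2ccc(-c3nc4cnc(N5CCN(C)CC5)cn4c3Nc3ccc(Br)cc3)cc12`, gives 11.7%.

Among these three, compound 2 stands second highest, with all three values close together. Its nearest neighbour is compound 1, the step being a number 2.7 percentage points higher from compound 1 to compound 2 (within the scatter), and its furthest is compound 3, the step being a number 3.6 percentage points higher from compound 2 to compound 3 (within the scatter). The remaining pair, compound 1 and compound 3, shows a number 6.3 percentage points higher from compound 1 to compound 3 (within the scatter). Every measured step is therefore within the scatter, and all three compounds sit at a low level of inhibition.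

Compound 4, `COc1ccc(Nc2c(-c3ccc4[nH]nc(C)c4c3)nc3cnc(N4CCN(C)CC4)cn23)cc1OC`, is the next compound to be tested. Compared with compound 2 the change is 3,4-dimethoxyphenyl in place of 4-chlorophenyl on a nitrogen on an aromatic ring. All three measured steps concern swapping one halogen-bearing phenyl for another at this same nitrogen, and none of them moved the read-out beyond the scatter. For the measured compounds named here, no measured step introduces methoxy groups, so the new ring has no direct precedent here. With three small changes at this position all leaving the number where it was, the expectation for compound 4 is a step of about a number 0.9 percentage points higher from compound 2 to compound 4 (within the scatter), which is no change beyond the scatter. The estimated value for compound 4 in this assay is 9%, with a range from -4% to 24%.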

Compound 4, a percentage reported as inhibition, at one concentration (the size of the read-out at that concentration, not a potency): 0%
Beside the measured number, compound 4's estimate is 9 percentage points above it, within the range that was stated.
By their numbers in this assay, from the lowest: compounds 4, 1, 2 and 3 (each within the scatter of the next, the first and the last beyond it).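

For the compounds shown here, at this nitrogen on an aromatic ring, 3,4-dimethoxyphenyl gives the first step in this assay that passes the usual scatter, and that modest step is seen only against the 4-bromophenyl compound (a number 11.7 percentage points lower from compound 3 to compound 4 (beyond the scatter)). Set against the other two halogen-bearing phenyl groups, the same ring stays within the scatter (a number 8.1 percentage points lower from compound 2 to compound 4 (within the scatter); a number 5.4 percentage points lower from compound 1 to compound 4 (within the scatter)), so the position shows only a small and partial response to this change, visible between the two ends of a narrow set of numbers. Nothing available here offers an explanation for this step.

The compounds shown leave open whether a single methoxy group on the phenyl ring would read like the pair in compound 4, and whether an amine or a carboxylic acid on this ring would lift the number clear of the low level shared by all four compounds. All four numbers also come from one tested concentration, so they leave open how these compounds would compare across a range of concentrations.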